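Benzyl halogen exchange on the sulfonyl side chain

The source may report more compounds than this note shows. Statements on the series, on what has been measured and on what is new or still open speak of the compounds shown alone.

The series is followed in a functional assay (Platelet, plasma) for inhibition, with Homo sapiens as the target; a lower number here means a stronger inhibitor, a higher number a weaker inhibitor. Among the compounds with values here, compound 1, `CC1(C(=O)NS(=O)(=O)Cc2ccc(F)cc2F)CCN(c2nc3c(cc2C#N)C(=O)OC3)CC1`, gives 8760 nM and stands lowest of the three numbers measured so far. Compound 2, `N#Cc1cc2c(nc1N1CCC(F)(C(=O)NS(=O)(=O)c3ccc(Cl)s3)CC1)COC2=O`, gives 37100 nM, a number beyond the scatter above that of compound 1. Compound 3, `N#Cc1cc2c(nc1N1CCC(C(=O)NS(=O)(=O)Cc3ccccc3)CC1)CCCC2=O`, gives 117000 nM, the highest of the three and the furthest from compound 1, again beyond the scatter. Within the data shown here, both compound 2 and compound 3 differ from compound 1 in more than one place, so no single step between measured compounds can be read from these numbers.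

Compound 4, `CC1(C(=O)NS(=O)(=O)Cc2ccc(Cl)cc2)CCN(c2nc3c(cc2C#N)C(=O)OC3)CC1`, is not yet measured. It differs from compound 1 in one place: 4-chlorophenyl in place of 2,4-difluorophenyl on a saturated chain carbon bound to a sulfonyl sulfur. Among the measured compounds shown here, no measured pair isolates this exchange; the other two compounds alter the sulfonyl side chain together with other parts of the molecule. For the measured compounds named here, with no isolated precedent, the step from compound 1 to compound 4 is expected to stay within the scatter, with no clear direction, as a 1.1-fold higher number from compound 1 to compound 4 (0.06 log units; within the scatter). Compound 4 is therefore expected to give about 10000 nM in this assay, with a range from 3500 nM to 30000 nM.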

Compound 4, half-maximal inhibitory concentration: 3010 nM
For compound 4 the middle estimate is 3.3-fold (0.52 log units) above the measured one; measured number below the stated range.
By their numbers in this assay, from the lowest: compound 4; then compound 1; then compound 2; then compound 3.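

The benzyl position on the sulfonyl side chain now has its first isolated reading: in this assay, 4-chlorophenyl in place of 2,4-difluorophenyl on a saturated chain carbon bound to a sulfonyl sulfur gives a 2.9-fold lower number from compound 1 to compound 4 (0.46 log units; beyond the scatter) and stays a modest step, though beyond the scatter. The number therefore responds to the halogen pattern on this aromatic ring while the rest of compound 1 stays fixed, but the exchange removes two fluorine atoms and brings in one chlorine atom at once, so the step belongs to the whole exchange and cannot be divided between those atoms. Nothing at hand gives a measured basis for explaining the step.

The compounds shown leave open whether the single chlorine atom alone accounts for the step, since they include neither an unsubstituted benzyl nor a 4-fluorobenzyl group on the core of compound 1. They also leave open how this position would respond to a non-halogen group such as methoxy or a carboxylic acid on the aromatic ring, and whether the same exchange would hold on a different core.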